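Bromo to fluoro with only limits to go on

This account rests on a few compounds, and the source may have more. Where it says the series, first, only, none or still open, it means among the compounds named here.

Measured in an ADME assay on Vero cells (Chlorocebus sabaeus) for cytotoxicity, read by neutral red uptake (on this read-out higher numbers stand for lower toxicity in this test and lower numbers for higher toxicity in this test), each value a limit:
Compound 1 `CC(=O)C(=C/C=C/c1ccc(Br)cc1)C(C)=O`: > 16.2 uM
Compound 2 `CC1(C)CC(=O)C(=C/C=C/c2ccccc2)C(=O)C1`: > 18.7 uM
Compound 3 `CC1(C)CC(=O)C(=C/C=C/c2ccc(Br)cc2)C(=O)C1`: > 14.3 uM

Compound 3 has no exact number in this assay, and its > 14.3 uM is a limit. The other two compounds are also known only by limits, so the three cannot be ranked against one another.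

Compound 4 `CC1(C)CC(=O)C(=C/C=C/c2ccc(F)cc2)C(=O)C1` keeps the core of compound 3 and changes a single group: fluoro in place of bromo on an aromatic carbon. In words, this is fluoro in place of bromo on an aromatic carbon.

Going by the values given here, the only measured step bearing on this change is a step that the two limits leave unreadable from compound 2 to compound 3, at the same aromatic carbon, and it gives neither a size nor a direction. The change expected is therefore a step that the limit leaves unreadable from compound 3 to compound 4, which is estimated to lie within the usual scatter, with no direction favoured. Compound 4 may well be reported as a limit too. For compound 4 the estimated value is 18 uM, with an expected range from 10 uM to 40 uM.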

Compound 4, half-maximal toxic concentration: > 17.5 uM
Compound 4: no number, only a limit; the forecaster's own chance of this, stated with the estimate: 85%; the middle value is on the limit's open side.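

In this assay compound 4 gives > 17.5 uM, which is a limit and not a number. Compound 2 and compound 3 also have only limits, so neither step to compound 4 can be read. The compounds shown leave open whether hydrogen, bromo or fluoro on that aromatic carbon changes the half-maximal toxic concentration at all.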